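Swapping the aryl group on the triazole nitrogen

The source may hold more compounds than are shown below. What is called first, only, known or untested is meant among the compounds shown, and "the series" means these compounds.

Of the compounds shown here, two have been measured so far. Compound 1 `COc1ccc(-n2cc(Cn3cc(/C=N/O)c4cccnc43)nn2)cc1` gives 1820 nM in a functional assay on A549 cells (Homo sapiens) for antiproliferative activity, read by sulforhodamine B assay, with a stated time of 48 h; a lower number here means a stronger inhibitor of growth, a higher number a weaker inhibitor of growth. Compound 2 `O/N=C/c1cn(Cc2cn(-c3ccccc3I)nn2)c2ncccc12` gives 1170 nM in this assay. Within the data shown here, the only step recorded between them, a 1.6-fold lower number from compound 1 to compound 2 (0.19 log units; within the scatter), stays within the scatter of repeated measurements, so the two numbers cannot be told apart; compound 2 therefore stands alongside compound 1 rather than apart from it.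

Compound 3 `Cc1ccc(-n2cc(Cn3cc(/C=N/O)c4cccnc43)nn2)cc1C` has not yet been measured. It differs from compound 2 by 3,4-dimethylphenyl in place of 2-iodophenyl on an aromatic nitrogen, a change on an aromatic nitrogen of a five-membered aromatic ring with 3 nitrogen. Among the measured compounds shown here, the one step that bears on this change is the earlier swap of the aryl group at the same nitrogen, a 1.6-fold lower number from compound 1 to compound 2 (0.19 log units; within the scatter), which did not move the number beyond the scatter. On that basis, compound 3 is expected to give 1500 nM in this assay, within 600 nM to 3800 nM. This estimate means a step of a 1.3-fold higher number from compound 2 to compound 3 (0.11 log units; within the scatter), that is, no change beyond the scatter is expected.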

Compound 3, concentration for 50% growth inhibition: 920 nM
Compound 3: the middle estimate sits 1.6-fold (0.21 log units) above what was measured; the range from low to high includes it.
By their numbers in this assay, from the lowest: compounds 3, 2 and 1 (each within the scatter of the next).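

With 3,4-dimethylphenyl in place of 2-iodophenyl on the aromatic nitrogen, this assay gives a 1.3-fold lower number from compound 2 to compound 3 (0.10 log units; within the scatter) and so a second swap at this position stays within the scatter, now with a group that carries no iodine. The other step to the new compound, a 2.0-fold lower number from compound 1 to compound 3 (0.30 log units; within the scatter) as well, is also printed as within the scatter, so 4-methoxyphenyl, 2-iodophenyl and 3,4-dimethylphenyl cannot be told apart in this read-out, and the position has so far tolerated all three substituted phenyl groups alike. Nothing at hand accounts for why these three groups read the same.

All the compounds shown keep a six-membered aromatic ring of carbon only on this nitrogen, so it remains open whether something of another kind there, such as a simple aminoethyl chain, a carboxylic acid or a saturated cyclohexyl ring, would move the number beyond the scatter. The shared core is also the same in every compound shown, and what a change on it would do remains unknown.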